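A few compounds are considered here, and "the series" means these few. Any claim that something is new, unique, unknown or untested is made for them only; others in the source may bear on it.

In a functional assay on VCaP cells (Homo sapiens) for antiproliferative activity, read by CCK-8 assay, with a stated time of 6 days (on this read-out higher numbers stand for weaker inhibition and lower numbers for stronger inhibition), compound 3 `C[C@@H](Cn1ccc(-c2ccc(C#N)c(Cl)c2)n1)Nc1ccccc1` stands at > 30000 nM and this is a limit of the assay, not a number. With other groups on the same amine nitrogen, compound 1 `C[C@@H](Cn1ccc(-c2ccc(C#N)c(Cl)c2)n1)NC(=O)C1CC(=O)C1` gives 22500 nM as its reading and compound 2 `C[C@@H](Cn1ccc(-c2ccc(C#N)c(Cl)c2)n1)NS(=O)(=O)c1cccnc1` gives 2450 nM as its reading. Compound 4 `C[C@@H](Cn1ccc(-c2ccc(C#N)c(Cl)c2)n1)Nc1ncccn1` has pyrimidin-2-yl in place of phenyl on that amine nitrogen pyrimidin-2-yl in place of phenyl on an amine nitrogen and keeps the shared core. Three measured steps at this nitrogen bear on the change: a 9.2-fold lower number from compound 1 to compound 2 (0.96 log units; beyond the scatter) and then an at least 12-fold higher number from compound 2 to compound 3 (1.08 log units; beyond the scatter) and also an at least 1.3-fold higher number from compound 1 to compound 3 (0.12 log units; that floor lies within the scatter) as the third. None of them swaps one aromatic ring for another directly on the nitrogen, so they guide the estimate only loosely. Taking an at least 12-fold higher number from compound 2 to compound 3 (1.08 log units; beyond the scatter) as the outer size of change seen here, a modest step towards a lower number is expected in this assay and a reading at the limit remains possible. The expected change is an at least 1.5-fold lower number from compound 3 to compound 4 (0.17 log units; that floor lies within the scatter) on this estimate. For compound 4 the estimated value is 20000 nM with an expected range from 6000 nM to 40000 nM in this read-out.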

Compound 4, half-maximal inhibitory concentration: 480 nM
The estimate for compound 4 lay 42-fold (1.62 log units) above the measured number, and the stated range ends above it.
By their numbers in this assay, from the lowest: compound 4; then compound 2; then compound 1. At a limit, above all of these: compound 3.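

On an amine nitrogen whose other neighbour is a saturated chain carbon, the exchange of phenyl for pyrimidin-2-yl, which keeps the count of 6 heavy atoms and alters only the ring's make-up, gives an at least 62-fold lower number from compound 3 to compound 4 (1.79 log units; beyond the scatter) in this assay. That step is only a floor, since compound 3 stands at a limit of the assay and not at a number: the limit of > 30000 nM in this assay, at which 1 of the 4 values shown sits.

The (pyridin-3-yl)sulfonyl and (3-oxocyclobutyl)carbonyl groups also give way to pyrimidin-2-yl, with a 5.1-fold lower number from compound 2 to compound 4 (0.71 log units; beyond the scatter) and a 47-fold lower number from compound 1 to compound 4 (1.67 log units; beyond the scatter), so an aromatic ring set directly on this nitrogen does not in itself bring a weak reading, with compound 3 as the case that goes the other way.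

The compounds shown leave open whether a pyridinyl ring, with a single ring nitrogen, would carry the same step. They also leave open how a methyl group or an amine on the pyrimidin-2-yl ring would change the reading.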